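This account rests on a few compounds, and the source may have more. Where it says the series, first, only, none or still open, it means among the compounds named here.

Measured so far in a toxicity assay on HepG2 2.2.15 cells (Homo sapiens) for cytotoxicity, read by CellTiter-Glo (a higher number here means that more compound is tolerated, a lower number that less compound is tolerated), as half-maximal cytotoxic concentration:

- compound 1 `O=C1CC(Oc2ncccn2)CN1c1cnn2c1CN(C(=O)Nc1cc(F)c(F)c(F)c1)C(C1CC1)C2` gives > 200000 nM as a limit
- compound 2 `CC1CCn2ncc(N3CC(c4ccccc4)CC3=O)c2CN1C(=O)Nc1cc(F)c(F)c(F)c1` gives > 2000 nM as a limit
- compound 3 `O=C1OC(c2ccc(F)cc2)CN1c1cnn2c1CN(C(=O)Nc1cc(F)c(F)c(F)c1)C(C1CC1)C2` gives 3560 nM as a number

Compound 1 is known only through the limit > 200000 nM and has no exact number. Compound 4 `O=C1CC(Oc2ncc(F)cn2)CN1c1cnn2c1CN(C(=O)Nc1cc(F)c(F)c(F)c1)C(C1CC1)C2` departs from compound 1 at a single place: fluoro in place of hydrogen on an aromatic carbon and so pyrimidin-2-yl becomes 5-fluoropyrimidin-2-yl, with fluoro in place of hydrogen on an aromatic carbon, para to a large group.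

Among the compounds with values here, no measured pair shows this change on its own. On the structural change alone, no step beyond the usual scatter is expected in this assay in either direction. The expectation is anchored on compound 1 with its limit of > 200000 nM as the nearest measured neighbour. The estimated step of an at least 1.3-fold lower number from compound 1 to compound 4 (0.12 log units; that floor lies within the scatter) is expected to stay within the scatter, and a further limit may well be reported. For compound 4 the estimate is 150000 nM with an expected range from 30000 nM to 300000 nM as its bounds.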

Compound 4, half-maximal cytotoxic concentration: 96200 nM
Beside the measured number, compound 4's estimate is 1.6-fold (0.19 log units) above it, and the stated range covers the measured number.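

In this assay, within the data shown here, the change from pyrimidin-2-yl to 5-fluoropyrimidin-2-yl is the only single-place change, and it moves the number beyond the scatter: an at least 2.0-fold lower number from compound 1 to compound 4 (0.31 log units; beyond the scatter). Fluoro in place of hydrogen on this aromatic carbon, para to a large group, is therefore not silent here, and less compound is tolerated with it on the ring. The step is only a floor on the true size of the change, because compound 1 is known solely through a limit: the limit of > 200000 nM in this assay, at which 1 of the 4 values shown sits.

Going by these compounds, whether chloro, methyl or methoxy at the same place would shift the number in the same way remains open. Also open, on these data alone, is whether fluoro has the same effect on a phenyl in place of the pyrimidine, since compound 2 and compound 3 differ from compound 1 in more than one place.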